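Alkoxy group enlargement on a fluorinated bicyclic amino acid

A few compounds are considered here, and "the series" means these few. Any claim that something is new, unique, unknown or untested is made for them only; others in the source may bear on it.

Measured compounds and their values:
- Compound 1 `CO[C@@H]1C[C@@H]2[C@H]([C@]1(N)C(=O)O)[C@@]2(F)C(=O)O`: 39.2 nM
- Compound 2 `CCC(C)O[C@@H]1C[C@@H]2[C@H]([C@]1(N)C(=O)O)[C@@]2(F)C(=O)O`: 6.68 nM

Both compounds were tested in an assay on CHO cells for binding affinity to metabotropic glutamate receptor 2 (Rattus norvegicus); a higher number here means a weaker inhibitor, a lower number a stronger inhibitor. Compound 2 `CCC(C)O[C@@H]1C[C@@H]2[C@H]([C@]1(N)C(=O)O)[C@@]2(F)C(=O)O` gives 6.68 nM, the lowest of the two numbers, with compound 1 as its nearest neighbour. Going by the values given here, the only measured step, a 5.9-fold lower number from compound 1 to compound 2 (0.77 log units; beyond the scatter), shows that a larger group on the oxygen on a saturated carbon went with a lower number.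

Compound 3 `N[C@]1(C(=O)O)[C@H]2[C@@H](C[C@H]1OCc1ccccc1)[C@]2(F)C(=O)O` has not yet been measured. The change is benzyl in place of sec-butyl on an oxygen on a saturated carbon. Among the compounds with values here, no measured step compares a benzyl with a sec-butyl here, so the measured step is only indirectly relevant: it suggests that enlarging this group does not hurt. A small step, in either direction and probably within the scatter, is therefore expected: a 1.2-fold lower number from compound 2 to compound 3 (0.08 log units; within the scatter). For compound 3 the estimate in this assay is 5.5 nM, with a range from 1.5 nM to 20 nM.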

Compound 3, inhibition constant: 7.14 nM
Estimate against measurement, compound 3: 1.3-fold (0.11 log units) below, and the stated range covers the measured number.
By their numbers in this assay, from the lowest: compounds 2 and 3 (each within the scatter of the next); then compound 1.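

In this assay, benzyl in place of sec-butyl on the oxygen gives a 1.1-fold higher number from compound 2 to compound 3 (0.03 log units; within the scatter), so a group with a six-membered aromatic ring of carbon only and a sec-butyl group with no ring read alike at this position. Against the methyl of compound 1, benzyl gives a 5.5-fold lower number from compound 1 to compound 3 (0.74 log units; beyond the scatter), which shows that the lower number is not confined to sec-butyl: both larger groups on this oxygen go with it. Nothing measured here explains this behaviour.

The compounds shown leave open how far this tolerance extends, for instance to a longer chain such as n-hexyl or to a benzyl whose ring carries a chlorine. On these data alone, it also remains open whether a group bearing an amine or a carboxylic acid on this oxygen would read the same.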